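Estimating compound 4 after a larger, more hydroxylated ring enters

The source may report more compounds than this note shows. Statements on the series, on what has been measured and on what is new or still open speak of the compounds shown alone.

Measured so far:
compound 1 `CC1(C)O[C@H]2O[C@H](Cn3cc(CN4C(=O)/C(=N\Nc5ccccc5)c5ccccc54)nn3)[C@H](O)[C@H]2O1`: 82100 nM
compound 2 `CC1(C)O[C@H]2O[C@H](Cn3cc(CN4C(=O)/C(=N\Nc5ccc(Br)cc5)c5ccccc54)nn3)[C@H](O)[C@H]2O1`: 72900 nM
compound 3 `CC1(C)O[C@H]2O[C@H](Cn3cc(CN4C(=O)/C(=N\Nc5cccc(Cl)c5)c5ccccc54)nn3)[C@H](O)[C@H]2O1`: 70000 nM

In an ADME assay on Vero cells (Chlorocebus sabaeus) for cytotoxicity, read by fluorescence and resazurin assay, with a stated time of 3 days (on this read-out higher numbers stand for lower toxicity in this test and lower numbers for higher toxicity in this test), compound 1 gives 82100 nM, the highest of the three numbers, yet compound 2 and compound 3 lie within the scatter of it: a 1.1-fold lower number from compound 1 to compound 2 (0.05 log units; within the scatter) and a 1.2-fold lower number from compound 1 to compound 3 (0.07 log units; within the scatter). Compound 4 `O=C1/C(=N\Nc2ccccc2)c2ccccc2N1Cc1cn(O[C@@H]2O[C@H](CO)[C@@H](O)[C@H](O)[C@H]2O)nn1` differs from compound 1 in one place: a group of 12 heavy atoms (6 carbon, 6 oxygen; one six-membered non-aromatic ring with 1 hetero atom) in place of a group of 12 heavy atoms (8 carbon, 4 oxygen; one five-membered non-aromatic ring with 1 hetero atom, one five-membered non-aromatic ring with 2 hetero atoms), on an aromatic nitrogen. Among the measured compounds shown here, none of the measured steps touches this part of the molecule; all three alter only the group on an amine nitrogen, and each stayed within the scatter, a 1.0-fold lower number from compound 2 to compound 3 (0.02 log units; within the scatter) included. For the measured compounds named here, no measured step therefore tells how this exchange acts, and the expected step of a 1.0-fold higher number from compound 1 to compound 4 (0.02 log units; within the scatter) is none beyond the scatter. Compound 4 is estimated at 85000 nM, expected to fall between 40000 nM and 180000 nM.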

Compound 4, half-maximal cytotoxic concentration: 88500 nM
Estimate against measurement, compound 4: 1.0-fold (0.02 log units) below; measured number inside the range.
By their numbers in this assay, from the lowest: compounds 3, 2, 1 and 4 (each within the scatter of the next).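

The earlier steps shown here varied only the group on the amine nitrogen, while this one replaces the group on the aromatic nitrogen. In this assay, putting (3,4,5-trihydroxy-6-(hydroxymethyl)oxan-2-yl)oxy in place of the group with two five-membered rings gives a 1.1-fold higher number from compound 1 to compound 4 (0.03 log units; within the scatter) and so stays within the scatter, even though the ring type and the count of hydrogen-bond donors both differ. Nothing available explains this result. From the compounds shown here alone, whether an amine or a carboxylic acid on this nitrogen would also stay within the scatter remains open. So does whether this exchange would behave the same way on compound 2 or compound 3.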